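The source may report more compounds than this note shows. Statements on the series, on what has been measured and on what is new or still open speak of the compounds shown alone.

Measured in an ADME assay on CHO cells (Cricetulus griseus) for cytotoxicity, read by MTT assay; a lower number here means a stronger inhibitor, a higher number a weaker inhibitor:
compound 1, `Cc1cc(C)n(-c2nc(C(F)(F)F)cc(=O)[nH]2)n1`, gives 150000 nM;
compound 2, `Cc1cc(C2CC2)n(-c2nc(C(F)(F)F)cc(=O)[nH]2)n1`, gives 78000 nM;
compound 3, `Cc1cc(-c2ccccc2)n(-c2nc(C(F)(F)F)cc(=O)[nH]2)n1`, gives > 50000 nM, which is a limit of the assay and not a number.

Compound 3 therefore stands only as a limit in this assay, with no exact number. Compound 4, `CCNc1cc(C)nn1-c1nc(C(F)(F)F)cc(=O)[nH]1`, is not yet measured; it differs from compound 3 by ethylamino in place of phenyl on an aromatic carbon. Of the measured steps, a 1.9-fold lower number from compound 1 to compound 2 (0.28 log units; within the scatter); a step that the limit leaves unreadable from compound 1 to compound 3 and a step that the limit leaves unreadable from compound 2 to compound 3 are both unreadable because of the limit of > 50000 nM in this assay, at which 1 of the 3 values shown sits. None of these steps involves an ethylamino group, so the expectation rests on the weak numbers of compound 1 and compound 2 alone, with no step beyond the scatter expected. Compound 4 is expected to give 100000 nM, within a range from 40000 nM to 250000 nM. This estimate means a step that the limit leaves unreadable from compound 3 to compound 4.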

Compound 4, half-maximal inhibitory concentration: 8000 nM
Beside the measured number, compound 4's estimate is 13-fold (1.10 log units) above it; measured number outside the range, below it.
By their numbers in this assay, from the lowest: compound 4; then compounds 2 and 1 (each within the scatter of the next).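

Ethylamino on this aromatic carbon gives a 19-fold lower number from compound 1 to compound 4 (1.27 log units; beyond the scatter) and a 9.8-fold lower number from compound 2 to compound 4 (0.99 log units; beyond the scatter) in this assay, so this position can register a change of group, which the within-scatter step from methyl to cyclopropyl did not show. Compound 3 gives > 50000 nM, a limit of the assay and not a number. Even so, an at least 6.2-fold lower number from compound 3 to compound 4 (0.79 log units; beyond the scatter) can be read, so ethylamino also stands apart from phenyl.

Still open, as far as these compounds go, is whether the step follows the nitrogen or the ethyl chain. A methylamino, dimethylamino or propyl group on the same carbon would separate the two.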